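A few compounds are considered here, and "the series" means these few. Any claim that something is new, unique, unknown or untested is made for them only; others in the source may bear on it.

Compound 1 `COc1cccc(N2CCN(c3ccc(C(=O)/C=C/c4ccccc4)cc3)CC2)c1` gives 16% in a functional assay on the whole organism (strain Kunming) for inhibition, with Mus musculus as the target, with a stated time of 1 h, at a dose of 40 mg/kg by the oral route; a lower number here means less inhibition, a higher number more inhibition at the dose given (going by the name of the read-out).
Compound 2 `Cc1ccc(N2CCN(c3ccc(C(=O)/C=C/c4ccccc4)cc3)CC2)cc1` gives 2.85% in this assay.

For the measured compounds named here, compound 2 stands lowest of the two numbers in this assay; its only neighbour is compound 1, and the step of a number 13.2 percentage points lower from compound 1 to compound 2 (beyond the scatter) lies beyond the scatter. Compound 3 `O=C(/C=C/c1ccccc1)c1ccc(N2CCN(c3cccc(C(F)(F)F)c3)CC2)cc1` differs from compound 2 by 3-(trifluoromethyl)phenyl in place of 4-methylphenyl on an amine nitrogen in a ring. Going by the values given here, the one measured step, a number 13.2 percentage points lower from compound 1 to compound 2 (beyond the scatter), concerns the same amine nitrogen in a ring but exchanges 3-methoxyphenyl for 4-methylphenyl, so no measured pair carries the 3-(trifluoromethyl)phenyl group and no step bears on it directly. What the two values show is that the 3-methoxyphenyl compound 1 sits above the 4-methylphenyl compound 2. On that slim basis a modest rise in this assay is expected for compound 3, of about a number 7.2 percentage points higher from compound 2 to compound 3 (within the scatter), though a result within the scatter of compound 2 cannot be excluded. Compound 3 is therefore estimated at 10%, with a range from 0% to 25%.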

Compound 3, a percentage reported as inhibition, in the whole organism at one dose (the size of the read-out at that dose, not a potency): 25%
The estimate for compound 3 lay 15 percentage points below the measured number, within the range that was stated.
By their numbers in this assay, from the lowest: compound 2; then compounds 1 and 3 (each within the scatter of the next).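

Compound 2 is now the outlier rather than compound 1: 3-(trifluoromethyl)phenyl on the amine nitrogen in a ring gives a number 22.2 percentage points higher from compound 2 to compound 3 (beyond the scatter) in this assay, the second step beyond the scatter to separate the 4-methylphenyl compound from another aryl group. Trifluoromethyl in place of methoxy on an aromatic carbon gives a number 9 percentage points higher from compound 1 to compound 3 (within the scatter), so this assay does not tell these two groups apart, and the higher reading on this nitrogen is shared by two different groups named at the 3-position of the phenyl ring. Nothing available accounts for these differences.

The compounds shown change both the group and its named ring position together, so whether the low reading of compound 2 follows the methyl group or its place on the ring stays open. A 3-methylphenyl or 4-(trifluoromethyl)phenyl group on that nitrogen would separate the two.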